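Swapping the 3-(4-fluorophenyl)propyl group of compound 1

A few compounds are considered here, and "the series" means these few. Any claim that something is new, unique, unknown or untested is made for them only; others in the source may bear on it.

Compound 1 `Cc1nc(C)c([C@H](OC(C)(C)C)C(=O)O)c(N2CCC(C)(C)CC2)c1-c1ccc(CCCc2ccc(F)cc2)cc1` stands at the edge of the measurable range in a toxicity assay on MT2 cells (Homo sapiens) for cytotoxicity, read by XTT assay, with a stated time of 4 days; on this read-out lower numbers stand for higher toxicity in this test and higher numbers for lower toxicity in this test. Compound 1 gives >= 32000 nM, which is a limit of the assay and not a number. Compound 2 `Cc1nc(C)c([C@H](OC(C)(C)C)C(=O)O)c(N2CCC(C)(C)CC2)c1-c1ccc(OC2COCC2c2ccc(F)cc2)cc1` gives >= 32000 nM; >= 32000 nM (2 entries), which is also a limit. Compound 3 `Cc1ncsc1CCOc1ccc(-c2c(C)nc(C)c([C@H](OC(C)(C)C)C(=O)O)c2N2CCC(C)(C)CC2)cc1` carries 2-(4-methyl-1,3-thiazol-5-yl)ethoxy in place of 3-(4-fluorophenyl)propyl on an aromatic carbon. Among the measured compounds shown here, no measured step covers this change. In this assay, the expected step of an at least 1.0-fold lower number from compound 1 to compound 3 (0.02 log units; that floor lies within the scatter) stays within the usual scatter. The estimated value for compound 3 is 30000 nM, with an expected range of 12000 nM to 50000 nM.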

Compound 3, half-maximal cytotoxic concentration: >= 25000 nM
Compound 3: no number, only a limit; the forecaster's own chance of this, stated with the estimate: 60%; the middle value does not contradict the limit.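

In this assay, among the compounds shown here, compound 1 and compound 3 are both recorded only as limits, so no step between them can be read. The compounds shown leave open whether 2-(4-methyl-1,3-thiazol-5-yl)ethoxy in place of 3-(4-fluorophenyl)propyl changes the read-out at all.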